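A few compounds are considered here, and "the series" means these few. Any claim that something is new, unique, unknown or untested is made for them only; others in the source may bear on it.

In an ADME assay on S9 fraction from liver (Homo sapiens) for metabolic stability, with a stated time of 1 h (a lower number here means that less of the compound is left, a higher number that more of the compound is left), compound 1 `N#Cc1cnc(NCc2cnccc2C(F)(F)F)cc1N[C@H]1C[C@H](O)C1` gives 96% and compound 2 `N#Cc1cnc(NCc2cnccc2C(F)(F)F)cc1NC[C@H]1C[C@@H](O)C1` gives 84% while compound 3 `N#Cc1cnc(NCc2cnccc2C(F)(F)F)cc1N[C@H]1CC[C@@H](O)CC1` gives 33% as the lowest of the three. The measured steps are a number 63 percentage points lower from compound 1 to compound 3 (beyond the scatter) and a number 51 percentage points lower from compound 2 to compound 3 (beyond the scatter) on going to 4-hydroxycyclohexyl, and a number 12 percentage points lower from compound 1 to compound 2 (beyond the scatter) on going to (3-hydroxycyclobutyl)methyl. Compound 4 `N#Cc1cnc(NCc2cnccc2C(F)(F)F)cc1N[C@H]1CC[C@H](O)CC1` keeps 4-hydroxycyclohexyl, and the change is this: the two compounds have the same atoms and bonds and differ only in configuration as drawn: 2 of 2 stereo elements differ (all stereocentres are inverted: mirror images); a stereocentre at a saturated ring carbon is drawn s in compound 3 and r in compound 4; a stereocentre at a saturated ring carbon is drawn s in compound 3 and r in compound 4. Within the data shown here, none of the measured steps changes configuration alone, so they bear on it only indirectly. Compound 3 at 33% leaves more room upward than downward, so a moderate rise is expected, with wide uncertainty. The estimated change is a number 12 percentage points higher from compound 3 to compound 4 (beyond the scatter). For compound 4 the estimated value is 45% within a range from 20% to 75%.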

Compound 4, percent of the compound remaining: 30%
Compound 4: the middle estimate sits 15 percentage points above what was measured; low and high end bracket the measured number.
By their numbers in this assay, from the lowest: compounds 4 and 3 (each within the scatter of the next); then compound 2; then compound 1.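

In this assay, the two compounds carrying 4-hydroxycyclohexyl cannot be told apart when both stereocentres are inverted, a number 3 percentage points lower from compound 3 to compound 4 (within the scatter). The configuration as drawn therefore does not separate them, and the large steps from the smaller rings recur with the other configuration: a number 54 percentage points lower from compound 2 to compound 4 (beyond the scatter) and a number 66 percentage points lower from compound 1 to compound 4 (beyond the scatter). The comparison between the pair is a clean one: the fact that compounds 3 and 4 differ only in the configuration as drawn

Going by these compounds, all four compounds carry a hydroxyl group on the ring, so its part in these numbers stays open. A 4-aminocyclohexyl or 4-methoxycyclohexyl group on the same nitrogen would bear on that question.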